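Swapping an Aryl Ether for a Piperidine Ether

The source may report more compounds than this note shows. Statements on the series, on what has been measured and on what is new or still open speak of the compounds shown alone.

Compound 2 `CCS(=O)(=O)Nc1ccc(Oc2ccc(C(F)(F)F)cc2)c(-c2cn(C)c(=O)c3[nH]ccc23)c1` was tested in an ADME assay on microsomes from liver (Homo sapiens) for metabolic stability, read by HPLC, using NADPH, with stated times of 5 min and 60 min, tested at 10 uM (a lower number here means slower removal, a higher number faster removal of the compound), and gives 128 mL/min/kg. Among the three compounds measured so far it holds the second highest number. Its nearest neighbour is compound 3 `Cn1cc(-c2cc(NS(C)(=O)=O)ccc2Oc2ccc(F)cc2F)c2cc[nH]c2c1=O`, which gives 155 mL/min/kg; these two lie within the scatter of the method. Compound 1 `Cn1cc(-c2cc(C(N)=O)ccc2Oc2ccccc2)c2cc[nH]c2c1=O` gives 48.3 mL/min/kg, a number lower than that of compound 2 by more than the scatter. Compound 4 `CCS(=O)(=O)Nc1ccc(OC2CCN(C)CC2)c(-c2cn(C)c(=O)c3[nH]ccc23)c1` has not yet been measured. It differs from compound 2 in one place: 1-methylpiperidin-4-yl in place of 4-(trifluoromethyl)phenyl on an oxygen on an aromatic ring. Among the compounds with values here, no measured pair shows a change of this kind, so there is no earlier step to lean on. A modest lowering of the number is expected, one that may stay within the scatter, so the step is estimated as a 1.6-fold lower number from compound 2 to compound 4 (0.20 log units; within the scatter). Compound 4 is therefore expected to give 80 mL/min/kg, with a range from 35 mL/min/kg to 180 mL/min/kg.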

Compound 4, clearance: < 28.4 mL/min/kg
Compound 4: only a limit was reported (the forecaster's own chance of this, stated with the estimate: 5%); middle value at least 2.8-fold (0.44 log units) away from the limit.
By their numbers in this assay, from the lowest: compound 1; then compounds 2 and 3 (each within the scatter of the next). At a limit, below all of these: compound 4.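

In this assay, within the data shown here, putting 1-methylpiperidin-4-yl in place of 4-(trifluoromethyl)phenyl on an oxygen on an aromatic ring gives an at least 4.5-fold lower number from compound 2 to compound 4 (0.65 log units; beyond the scatter) and is the only single change measured at this place, so the group on that oxygen can shift the number beyond the scatter. Going by these compounds, the true size of the step stays unknown, as the result for compound 4 is a limit and not a number: the limit of < 28.4 mL/min/kg in this assay, at which 1 of the 4 values shown sits. The compounds shown leave open whether the ring nitrogen or the loss of the aromatic ring goes with this lower number. A cyclohexyl group on the same oxygen, with carbon in place of that nitrogen, would separate the two.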